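From 2-fluorophenyl to 4-fluorophenyl in compound 3

The source may hold more compounds than are shown below. What is called first, only, known or untested is meant among the compounds shown, and "the series" means these compounds.

In a functional assay on V79-379A cells (Cricetulus griseus) for cytotoxicity, read by MTT assay, in the presence of a further agent that is not named here (a lower number here means a stronger inhibitor, a higher number a weaker inhibitor), compound 1 (`COC1=CC(=O)c2c(c(CO)cn2C)C1=O`) gives 220000 nM and compound 2 (`COC1=CC(=O)c2c(c(COC(=O)c3ccccc3F)c(C)n2C)C1=O`) gives 164000 nM as its reading. These two values lie within the usual scatter of each other, so compound 2 stands level with compound 1. Compound 3 (`COC1=CC(=O)c2c(c(COC(=O)c3ccc(F)cc3)c(C)n2C)C1=O`) carries 4-fluorophenyl in place of 2-fluorophenyl on a carbonyl carbon. Among the compounds with values here, no measured pair shows a change of this kind. In this assay no direction is favoured, and the estimated step (a 1.0-fold lower number from compound 2 to compound 3 (0.01 log units; within the scatter)) is expected to stay within the scatter. Compound 3 is estimated at 160000 nM with an expected range from 90000 nM to 280000 nM in this test.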

Compound 3, half-maximal inhibitory concentration: 27000 nM
Compound 3: middle estimate off by 5.9-fold (0.77 log units), on the high side, and the stated range ends above it.
By their numbers in this assay, from the lowest: compound 3; then compounds 2 and 1 (each within the scatter of the next).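

In this assay, 4-fluorophenyl in place of 2-fluorophenyl on a carbonyl carbon gives a 6.1-fold lower number from compound 2 to compound 3 (0.78 log units; beyond the scatter) and so provides the first step beyond the scatter among these compounds. It shows that this position can distinguish between two groups with the same atoms, joined differently, which compounds 1 and 2 could not reveal. Nothing available explains this difference. The compounds shown leave open how a plain phenyl, a 4-chlorophenyl or a 4-aminophenyl would read at this position. They also leave open whether a carboxylic acid on that phenyl ring would be tolerated.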